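A few compounds are considered here, and "the series" means these few. Any claim that something is new, unique, unknown or untested is made for them only; others in the source may bear on it.

Compound 1 `O=C1O[C@H]([C@@H](O)Cn2cc(-c3ccc(Br)cc3)nn2)C(OCc2ccccc2)=C1OCc1ccccc1` — 9420 nM
Compound 2 `CCCCc1cn(C[C@H](O)[C@H]2OC(=O)C(OCc3ccccc3)=C2OCc2ccccc2)nn1` — 10400 nM
Compound 3 `Cc1ccc(-c2cn(C[C@H](O)[C@H]3OC(=O)C(OCc4ccccc4)=C3OCc3ccccc3)nn2)cc1` — only a limit, > 100000 nM

Of the compounds shown here, three sharing one core have been tested in a functional assay on HCT-116 cells (Homo sapiens) for antiproliferative activity, read by MTT assay, with a stated time of 72 h; on this read-out higher numbers stand for weaker inhibition and lower numbers for stronger inhibition. Compound 1 gives 9420 nM. Compound 2 gives 10400 nM; the difference between them, a 1.1-fold higher number from compound 1 to compound 2 (0.04 log units; within the scatter), is within the scatter, so the two cannot be told apart. Compound 3 gives only a limit, > 100000 nM, which is the limit of > 100000 nM in this assay, at which 1 of the 3 values shown sits. Against it the steps of an at least 10-fold higher number from compound 1 to compound 3 (1.02 log units; beyond the scatter) and an at least 9.6-fold higher number from compound 2 to compound 3 (0.98 log units; beyond the scatter) are both beyond the scatter.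

So compound 2 sits beside compound 1, with compound 3 apart from both as a limit. Compound 4 `O=C1O[C@H]([C@@H](O)Cn2cc(CNS(=O)(=O)c3ccc(Cl)cc3F)nn2)C(OCc2ccccc2)=C1OCc1ccccc1` differs from compound 2 in one place: ((4-chloro-2-fluorophenyl)sulfonyl)amino in place of propyl on a saturated chain carbon bound to an aromatic carbon. Among the measured compounds shown here, no measured step makes this kind of exchange. The nearest guide is a 1.1-fold higher number from compound 1 to compound 2 (0.04 log units; within the scatter), where swapping an aromatic group for a chain changed nothing beyond the scatter, while an at least 9.6-fold higher number from compound 2 to compound 3 (0.98 log units; beyond the scatter) shows that such a swap can also cost a great deal. Compound 4 is therefore expected to land near compound 2, with a wide range, as a 1.4-fold higher number from compound 2 to compound 4 (0.16 log units; within the scatter); the estimate for compound 4 is 15000 nM, between 4000 nM and 60000 nM.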

Compound 4, half-maximal inhibitory concentration: 21600 nM
Estimate against measurement, compound 4: 1.4-fold (0.16 log units) below; measured number inside the range.
By their numbers in this assay, from the lowest: compounds 1 and 2 (each within the scatter of the next); then compound 4. At a limit, above all of these: compound 3.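

In this assay the exchange of propyl for ((4-chloro-2-fluorophenyl)sulfonyl)amino on a saturated chain carbon bound to an aromatic carbon gives a 2.1-fold higher number from compound 2 to compound 4 (0.32 log units; beyond the scatter) and so counts as a modest step. This place on the chain therefore accepts a much larger group, one that brings an aromatic ring and a hydrogen-bond donor, at only a modest loss of inhibition, and compound 4 still gives a measured number rather than a limit. Nothing measured here explains the size of this step.

Which part of the new group, the sulfonyl, the amino hydrogen or the halogenated ring, accounts for the step remains open. So does whether an amine, a carboxylic acid or a chain longer than butyl at this place would stay close to compound 2.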